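A few compounds are considered here, and "the series" means these few. Any claim that something is new, unique, unknown or untested is made for them only; others in the source may bear on it.

Compound 1 `O=C(CSc1nc(Nc2ccccc2)c2ccccc2n1)Nc1cccc(Cl)c1` gives 12600 nM in a functional assay on PC-3 cells (Homo sapiens) for inhibition, read by MTT assay, with a stated time of 72 h; on this read-out higher numbers stand for weaker inhibition and lower numbers for stronger inhibition.
Compound 2 `O=C(CSc1nc(Nc2ccccc2)c2ccccc2n1)Nc1cccc([N+](=O)[O-])c1` gives 11800 nM in this assay.
Compound 3 `CCc1cccc(NC(=O)CSc2nc(Nc3ccccc3)c3ccccc3n2)c1` gives 11000 nM in this assay.

Compound 2 stands second highest of these three numbers, and its gaps to the others are within the scatter: a 1.1-fold lower number from compound 1 to compound 2 (0.03 log units; within the scatter) and a 1.1-fold lower number from compound 2 to compound 3 (0.03 log units; within the scatter). Compound 4 `O=C(CSc1nc(Nc2ccccc2)c2ccccc2n1)Nc1ccc(Cl)c(Cl)c1` has not been measured; it differs from compound 2 in one place: 3,4-dichlorophenyl in place of 3-nitrophenyl on an amide-type nitrogen. All three measured steps swap the group on the same aromatic carbon and each stays within the scatter, including a 1.1-fold lower number from compound 1 to compound 3 (0.06 log units; within the scatter). On that basis no step beyond the scatter is expected in this assay for compound 4, that is a 1.0-fold lower number from compound 2 to compound 4 (0.01 log units; within the scatter). Compound 4 is therefore estimated at 11500 nM, within a range from 5000 nM to 26000 nM.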

Compound 4, half-maximal inhibitory concentration: 12100 nM
The estimate for compound 4 lay 1.1-fold (0.02 log units) below the measured number, and the stated range covers the measured number.
By their numbers in this assay, from the lowest: compounds 3, 2, 4 and 1 (each within the scatter of the next).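

Earlier compounds swapped one group on the aromatic ring; compound 4 shows that adding a chlorine also leaves this assay unmoved, with chloro in place of hydrogen giving a 1.0-fold lower number from compound 1 to compound 4 (0.02 log units; within the scatter). Changing the whole group on the amide-type nitrogen is equally silent: 3,4-dichlorophenyl, which has no hydrogen-bond acceptors, in place of 3-nitrophenyl, which has two, gives a 1.0-fold higher number from compound 2 to compound 4 (0.01 log units; within the scatter), and in place of 3-ethylphenyl gives a 1.1-fold higher number from compound 3 to compound 4 (0.04 log units; within the scatter). Nothing available explains this flat result. Still open, as far as these compounds go, is whether an amine or a carboxylic acid on this ring would shift the number. A longer chain in place of the ring is equally untested here.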